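Acetyl in place of trifluoromethyl on a urea of phenylethylamine

The source may report more compounds than this note shows. Statements on the series, on what has been measured and on what is new or still open speak of the compounds shown alone.

Measured so far:
compound 1, `C[C@@H](NC(=O)Nc1cccc(C(F)(F)F)c1)c1ccccc1`, 72%
compound 2, `C[C@H](NC(=O)Nc1cccc(C(F)(F)F)c1)c1ccccc1`, 93%
compound 3, `CC(=O)c1ccccc1NC(=O)N[C@@H](C)c1ccccc1`, 97%

In an ADME assay on the whole organism with Oryza sativa as the target, tested at 1 uM (on this read-out higher numbers stand for a weaker effect at the one concentration tested and lower numbers for a stronger effect), compound 2 gives 93%, which is the second highest of the three numbers; compound 3 gives 97%, and the two lie within the scatter of each other, while compound 1 gives 72%, clearly lower. Within the data shown here, the only step measured so far is a number 21 percentage points higher from compound 1 to compound 2 (beyond the scatter), which rests on (the fact that compounds 1 and 2 differ only in the configuration as drawn).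

Compound 4, `CC(=O)c1cccc(NC(=O)N[C@@H](C)c2ccccc2)c1`, is not yet measured. It differs from compound 2 by acetyl in place of trifluoromethyl on an aromatic carbon. Among the measured compounds shown here, no measured step exchanges one group for another on that ring, so the stereochemical step says nothing about this change. Compound 3 also carries an acetyl and gives 97%, close to compound 2. On that basis the step of no change at the digits printed from compound 2 to compound 4 (within the scatter) is expected to stay within the scatter. Compound 4 is therefore estimated at 93%, with a range from 78% to 100%.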

Compound 4, a percentage reported as activity, at one concentration (the size of the read-out at that concentration, not a potency): 95%
Beside the measured number, compound 4's estimate is 2 percentage points below it; the measured number falls inside the stated range.
By their numbers in this assay, from the lowest: compound 1; then compounds 2, 4 and 3 (each within the scatter of the next).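

In this assay, among these compounds, putting acetyl in place of trifluoromethyl gives a number 2 percentage points higher from compound 2 to compound 4 (within the scatter) and is the first measured exchange of one group for another on this ring. On this aromatic carbon, meta to a large group, the two groups cannot be told apart in this read-out, although trifluoromethyl has no hydrogen-bond acceptor and acetyl has 1 hydrogen-bond acceptor. Nothing known about these compounds explains this result.

The compounds shown leave open whether acetyl gives a similar number with the stereocentre drawn as in compound 1, where trifluoromethyl gives 72% in this assay. They also leave open what an amine or a carboxylic acid would give on this same aromatic carbon.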